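A few compounds are considered here, and "the series" means these few. Any claim that something is new, unique, unknown or untested is made for them only; others in the source may bear on it.

Compound 1 `O=C1/C(=C/c2ccc(F)cc2)Cc2ccccc21`: 42200 nM
Compound 2 `O=C1/C(=C/c2cccc(Cl)c2)Cc2ccccc21`: 31800 nM

In a functional assay on CCRF-CEM cells (Homo sapiens) for inhibition (on this read-out higher numbers stand for weaker inhibition and lower numbers for stronger inhibition), compound 1 gives 42200 nM, the highest of the two numbers in hand. Its nearest neighbour, compound 2, gives 31800 nM, a gap that lies within the scatter, so the two cannot be told apart. Compound 3 `Cc1ccc(/C=C2\Cc3ccccc3C2=O)cc1` is not yet measured; it differs from compound 1 by methyl in place of fluoro on an aromatic carbon. Going by the values given here, no measured pair shows the effect of such a change, so in this assay the expected step is small and not beyond the scatter, in no clear direction: a 1.2-fold lower number from compound 1 to compound 3 (0.07 log units; within the scatter) is the step expected. For compound 3 the estimated value is 36000 nM, with a range from 15000 nM to 85000 nM.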

Compound 3, half-maximal inhibitory concentration: 67100 nM
Compound 3: middle estimate off by 1.9-fold (0.27 log units), on the low side; the measured number falls inside the stated range.
By their numbers in this assay, from the lowest: compounds 2, 1 and 3 (each within the scatter of the next, the first and the last beyond it).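

In this assay methyl in place of fluoro, on an aromatic carbon para to a large group, gives a 1.6-fold higher number from compound 1 to compound 3 (0.20 log units; within the scatter) and so leaves the two compounds indistinguishable. This position therefore tolerates the exchange of these two single-atom groups without a change that can be read beyond the scatter. Nothing at hand bears on the origin of this result.

On these data alone, whether an amine, a carboxylic acid or a longer chain at this position would give a number beyond the scatter stays open. So does the effect of any change to the shared core.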